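Amide aryl variation on the shared core

The compounds below may be only part of what the source reports. "The series", "measured", "known", "first", "only" and "open" are said of these compounds alone.

Measured so far:
compound 1 `COc1cccc(C(=O)Nc2nnc(/C=C/c3cc(OC)c(OC)c(OC)c3Br)s2)c1`: 60 nM
compound 2 `COc1ccc(C(=O)Nc2nnc(/C=C/c3cc(OC)c(OC)c(OC)c3Br)s2)cc1`: 150 nM
compound 3 `COc1cc(/C=C/c2nnc(NC(=O)c3ccccc3Br)s2)c(Br)c(OC)c1OC`: 210 nM

In a functional assay on A549 cells (Homo sapiens) for antiproliferative activity, read by MTT assay, with a stated time of 48 h (on this read-out lower numbers stand for stronger inhibition and higher numbers for weaker inhibition), compound 3 gives the highest of the three numbers; the gap to compound 2 is within the scatter, while the step of a 3.5-fold higher number from compound 1 to compound 3 (0.54 log units; beyond the scatter) lies beyond it. Compound 4 `COc1cc(/C=C/c2nnc(NC(=O)c3cccc(Cl)c3)s2)c(Br)c(OC)c1OC` differs from compound 3 by 3-chlorophenyl in place of 2-bromophenyl on a carbonyl carbon. The bearing steps are a 3.5-fold higher number from compound 1 to compound 3 (0.54 log units; beyond the scatter) and a 1.4-fold higher number from compound 2 to compound 3 (0.15 log units; within the scatter); the only other aryl with a group at the 3-position, compound 1, holds the lowest number. Among the measured compounds shown here, the change is therefore expected to give a lower number, a 2.6-fold lower number from compound 3 to compound 4 (0.42 log units; beyond the scatter), though no measured pair carries a halogen at that position. Compound 4 is estimated at 80 nM, in the range 35 nM to 200 nM.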

Compound 4, half-maximal inhibitory concentration: 70 nM
Estimate against measurement, compound 4: 1.1-fold (0.06 log units) above, and the stated range covers the measured number.
By their numbers in this assay, from the lowest: compounds 1 and 4 (each within the scatter of the next); then compounds 2 and 3 (each within the scatter of the next).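

In this assay, 3-chlorophenyl on the carbonyl carbon gives a 3.0-fold lower number from compound 3 to compound 4 (0.48 log units; beyond the scatter) and a 2.1-fold lower number from compound 2 to compound 4 (0.33 log units; beyond the scatter), so a halogen on this aryl does not by itself bring the higher number of compound 3. Chloro in place of methoxy on an aromatic carbon gives a 1.2-fold higher number from compound 1 to compound 4 (0.07 log units; within the scatter), so 3-chlorophenyl and 3-methoxyphenyl cannot be told apart here. Nothing at hand gives a reason for these steps.

As far as these compounds go, it remains open whether the gap between compound 3 and compound 4 follows the halogen or its place, which 2-chlorophenyl or 3-bromophenyl could separate. From the compounds shown here alone, how an amine or a carboxylic acid on this aryl would read also remains open.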